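The source may report more compounds than this note shows. Statements on the series, on what has been measured and on what is new or still open speak of the compounds shown alone.

Of the compounds shown here, two with the same core have been measured. Compound 1, `COc1cc2nc(N3CCN(C(=O)OCc4ccccc4)CC3)nc(N)c2cc1OC`, gives 63000 nM in a functional assay on PC-3 cells (Homo sapiens) for inhibition; a lower number here means a stronger inhibitor, a higher number a weaker inhibitor. Compound 2, `COc1cc2nc(N3CCN(S(=O)(=O)c4ccccc4[N+](=O)[O-])CC3)nc(N)c2cc1OC`, gives 35000 nM in this assay. Compound 2 thus shows the smaller of the two numbers, but its number and that of compound 1 lie within the usual scatter of each other, so neither compound can be called the stronger inhibitor on these data alone.

Compound 3, `COc1ccc(S(=O)(=O)N2CCN(c3nc(N)c4cc(OC)c(OC)cc4n3)CC2)cc1`, has not yet been measured. It differs from compound 2 in one place: 4-methoxyphenyl in place of 2-nitrophenyl on a sulfonyl sulfur. Among the compounds with values here, both measured compounds sit at weak inhibition, and the carbamate of compound 1 and the sulfonamide of compound 2 are within the scatter of each other, so there is no measured step here to anchor the size of this change. The exchange of one aryl group for another on the sulfonyl sulfur is expected to leave the number close to that of compound 2, with no step beyond the scatter, an expected step of a 1.2-fold lower number from compound 2 to compound 3 (0.07 log units; within the scatter). Compound 3 is therefore estimated at 30000 nM in this assay, within a range of 10000 nM to 90000 nM.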

Compound 3, half-maximal inhibitory concentration: 39000 nM
Compound 3: the middle estimate sits 1.3-fold (0.11 log units) below what was measured; low and high end bracket the measured number.
By their numbers in this assay, from the lowest: compounds 2, 3 and 1 (each within the scatter of the next).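

In this assay, within the data shown here, putting 4-methoxyphenyl in place of 2-nitrophenyl on a sulfonyl sulfur gives a 1.1-fold higher number from compound 2 to compound 3 (0.05 log units; within the scatter), the first step between compounds that differ in only one place. It shows that, for this one pair, replacing one aryl group with another at this position does not shift the number beyond the scatter, even though the exchange removes the nitrogen and changes the heavy-atom and hydrogen-bond-acceptor counts listed for the two groups. No supporting data bear on why the two compounds read alike, so this result stands as an observation only.

The step changes both the substituent and its printed ring number at once, so it leaves open how 4-nitrophenyl or 2-methoxyphenyl would read compared with compound 2 and compound 3, and so whether either feature matters on its own. It also leaves open whether anything at this position can move the number beyond the scatter, such as an unsubstituted phenyl, a simple methyl on the sulfonyl sulfur, or an aryl group carrying an amine or a carboxylic acid.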